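The source may hold more compounds than are shown below. What is called first, only, known or untested is meant among the compounds shown, and "the series" means these compounds.

Of the compounds shown here, three built on one shared core have been tested in a functional assay on HT-29 cells (Homo sapiens) for cytotoxicity, read by MTT assay, with a stated time of 72 h; a higher number here means a weaker inhibitor, a lower number a stronger inhibitor. Compound 1 `Cc1c(/N=C/c2ccc(N(C)C)cc2)c(=O)n(-c2ccccc2)n1C` gives 331000000 nM. Compound 2 `COc1ccc(/C=N/c2c(C)n(C)n(-c3ccccc3)c2=O)cc1` gives 589000000 nM, and compound 3 `COc1ccccc1/C=N/c1c(C)n(C)n(-c2ccccc2)c1=O` gives 70800000 nM. Among these three numbers compound 1 stands second highest: the move a 1.8-fold higher number from compound 1 to compound 2 (0.25 log units; within the scatter) leaves the two numbers within the scatter of one another, while compound 3 sits clearly lower, as the move an 8.3-fold lower number from compound 2 to compound 3 (0.92 log units; beyond the scatter) shows.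

Compound 4 `Cc1c(/N=C/c2ccc(O)cc2)c(=O)n(-c2ccccc2)n1C` has not yet been measured in this assay. It differs from compound 1 in one place: hydroxy in place of dimethylamino on an aromatic carbon. Within the data shown here, the one measured step that bears on this exchange is a 1.8-fold higher number from compound 1 to compound 2 (0.25 log units; within the scatter), where the same dimethylamino gave way to a methoxy at the same aromatic carbon and the numbers stayed within the scatter. For compound 4 the expected step of a 1.1-fold higher number from compound 1 to compound 4 (0.02 log units; within the scatter) is therefore small, with no clear direction. Compound 4 is estimated at 350000000 nM in this assay, with a likely range from 110000000 nM to 1100000000 nM.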

Compound 4, half-maximal inhibitory concentration: 389000000 nM
Compound 4: middle estimate off by 1.1-fold (0.05 log units), on the low side; measured number inside the range.
By their numbers in this assay, from the lowest: compound 3; then compounds 1, 4 and 2 (each within the scatter of the next).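

Hydroxy, with 1 heavy atom and 1 hydrogen-bond donor, replaces dimethylamino, with 3 heavy atoms and no donor, at this place para to a large group, yet in this assay the result is a 1.2-fold higher number from compound 1 to compound 4 (0.07 log units; within the scatter) and so gives no sign that this exchange matters. Taking the methyl off the oxygen of the methoxy group likewise gives a 1.5-fold lower number from compound 2 to compound 4 (0.18 log units; within the scatter) and leaves all three groups at this place inseparable, while the 2-methoxyphenyl group still stands apart, with a 5.5-fold higher number from compound 3 to compound 4 (0.74 log units; beyond the scatter) as the clear gap. No measurement offers a reason for either finding.

Going by these compounds, whether a carboxylic acid, a primary amine or a longer alkoxy chain at this place would also stay within the scatter remains open. So does whether a 2-hydroxyphenyl group would match the number of the 2-methoxyphenyl group.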